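Removing a Methyl Group from a Very Weak Inhibitor

The source may hold more compounds than are shown below. What is called first, only, known or untested is meant among the compounds shown, and "the series" means these compounds.

Compound 1 `Cc1ccc(NC(=O)Nc2nc(-c3cc4cc(Br)ccc4o3)cs2)cc1` was tested in a physicochemical assay, with a stated time of 6 min; a lower number here means a stronger inhibitor, a higher number a weaker inhibitor. In this assay compound 1 gives only a limit, > 200000 nM, not a number. This is recorded as the limit of > 200000 nM in this assay, at which 1 of the 2 values shown sits. A second compound, compound 2 `O=C(Nc1ccc(F)cc1)Nc1nc(-c2cc3cc([N+](=O)[O-])ccc3o2)cs1`, shares the core but carries different groups at both ends; in this assay compound 2 gives 123000 nM. For the measured compounds named here, no single-change step connects compound 1 and compound 2, so their two values show only that both sit at the weak end of what this assay can report.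

Compound 3 `O=C(Nc1ccccc1)Nc1nc(-c2cc3cc(Br)ccc3o2)cs1` differs from compound 1 in one place: hydrogen in place of methyl on an aromatic carbon. Cut one bond further out, the change reads 4-methylphenyl to phenyl. Nothing among the measured compounds shows what removing the methyl does here, so no cause can be given. The expected step is a number no higher from compound 1 to compound 3 (the limit leaves the size open), no larger than the usual scatter, in no particular direction. Compound 3 is therefore expected to give about 200000 nM in this assay, within a range from 100000 nM to 400000 nM, with a fair chance that only a limit is reported again.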

Compound 3, half-maximal inhibitory concentration: > 200000 nM
Compound 3 was reported as a limit; the forecaster's own chance of this, stated with the estimate: 55%; the middle value sits exactly at the limit.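

In this assay compound 3, like compound 1, gives only a limit and not a number, so no step can be read between these two compounds: the limit of > 200000 nM in this assay, at which 2 of the 3 values shown sit.

The compounds shown leave open whether changing 4-methylphenyl to phenyl alters inhibition at all, and how strongly either compound actually inhibits.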